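The compounds below may be only part of what the source reports. "The series", "measured", "known", "first", "only" and "open" are said of these compounds alone.

In a functional assay on SK-OV-3 cells (Homo sapiens) for inhibition, read by CCK-8 assay, with a stated time of 70 h (on this read-out lower numbers stand for stronger inhibition and higher numbers for weaker inhibition), three compounds have been measured so far. Compound 1 `c1ccc(COc2ccc(OCCOCCOC3CCCC3)cc2)cc1` gives > 100000 nM in this assay, which is a limit of the assay rather than a number. Compound 3 `c1ccc(COc2ccc(OCCOCCNC3CCCCCC3)cc2)cc1` gives 7460 nM in this assay. Compound 2 `COc1ccc(COc2ccc(OCCOCCNC3CCCC3)cc2)cc1` gives 15700 nM in this assay, the highest of the two numbers; its nearest neighbour is compound 3, whose value is lower by a margin beyond the scatter. Among the measured compounds shown here, the single step between measured compounds that differ in one place is large: an at least 13-fold lower number from compound 1 to compound 3 (1.12 log units; beyond the scatter), with cycloheptylamino in place of cyclopentyloxy on a saturated chain carbon, two bonds along the chain from an oxygen on a saturated carbon.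

Compound 4 `O=[N+]([O-])c1ccc(COc2ccc(OCCOCCNC3CCCC3)cc2)cc1` has not yet been measured. It differs from compound 2 by nitro in place of methoxy on an aromatic carbon. For the measured compounds named here, no measured step touches the group on this aromatic carbon, so the measured compounds give no guide to how a nitro compares with a methoxy at this place. The expected step is a 1.2-fold lower number from compound 2 to compound 4 (0.08 log units; within the scatter), a change not beyond the scatter. Compound 4 is estimated at 13000 nM in this assay, within a range from 4000 nM to 45000 nM.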

Compound 4, half-maximal inhibitory concentration: 20300 nM
Beside the measured number, compound 4's estimate is 1.6-fold (0.19 log units) below it; the range from low to high includes it.
By their numbers in this assay, from the lowest: compound 3; then compounds 2 and 4 (each within the scatter of the next). At a limit, above all of these: compound 1.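

In this assay, among the compounds shown here, nitro in place of methoxy on an aromatic carbon, para to a large group, gives a 1.3-fold higher number from compound 2 to compound 4 (0.11 log units; within the scatter) as the first measured step at this position. So 4-methoxyphenyl and 4-nitrophenyl cannot be told apart on this read-out, even though the two groups differ in their atoms and in their count of hydrogen-bond acceptors. Nothing measured here bears on why these two groups read alike.

The compounds shown leave open whether a different group on this aromatic carbon, such as an amine or a carboxylic acid, would move the number beyond the scatter. They also leave open whether the same swap would read alike in a compound carrying the cycloheptylamino group of compound 3.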